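Swapping a fluoropyridine for an aminoethylamine chain

This account rests on a few compounds, and the source may have more. Where it says the series, first, only, none or still open, it means among the compounds named here.

Measured so far:
compound 1 `COc1cc(OC)c2c(=O)cc(-c3ccc(OC4CCN(C)CC4)cc3)oc2c1` — 28%
compound 2 `COc1cc(OC)c2c(=O)cc(-c3ccc(-c4ccc(F)nc4)cc3)oc2c1` — "not active" (no number reported)

In a functional assay (Homo sapiens) for antiproliferative activity, read by resazurin assay, with a stated time of 48 h, tested at 5 uM (on this read-out higher numbers stand for a stronger effect at the one concentration tested and lower numbers for a weaker effect), compound 1 gives 28%. In this assay compound 2 was recorded as "not active" (no number reported), so it stands at the weak end without a figure of its own. Compound 3 `COc1cc(OC)c2c(=O)cc(-c3ccc(NCCN(C)C)cc3)oc2c1` has not yet been tested. Going from compound 2 to compound 3, ((2-(dimethylamino)ethyl)amino in place of 6-fluoropyridin-3-yl on an aromatic carbon). A gain in this assay beyond the usual scatter is expected, because compound 1, which also carries an amine group, gives 28%. Compound 3 is estimated at 25%, with a range from 5% to 45%.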

Compound 3, a percentage reported as inhibition, at one concentration (the size of the read-out at that concentration, not a potency): 30%
Estimate against measurement, compound 3: 5 percentage points below, within the range that was stated.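

Placing (2-(dimethylamino)ethyl)amino in the spot held by (1-methylpiperidin-4-yl)oxy gives a number 2 percentage points higher from compound 1 to compound 3 (within the scatter) in this assay, so an open chain and a ring-bearing group cannot be told apart at this position. The step from compound 2 cannot be read as a size, since compound 2 has no number. No measurement here gives a cause for this result.

Still open, on these data alone, is whether an amine is needed at this position at all. A carboxylic acid or a morpholine ring on this aromatic carbon would bear on that question.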